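Halophenyl exchange on the aromatic nitrogen: compound 4

The source may report more compounds than this note shows. Statements on the series, on what has been measured and on what is new or still open speak of the compounds shown alone.

Compound 1 `Cn1ccc2c(Oc3ccc(NC(=O)c4nn(-c5ccc(Cl)c(F)c5)ccc4=O)cc3)ccnc21` gives 32700 nM in a functional assay on PC-3 cells (Homo sapiens) for cytotoxicity, read by MTT assay, with a stated time of 72 h; a higher number here means a weaker inhibitor, a lower number a stronger inhibitor. Compound 2 `Cn1ccc2c(Oc3ccc(NC(=O)c4nn(-c5ccc(Cl)cc5)ccc4=O)cc3F)ccnc21` reaches only the limit > 60000 nM in this assay. Compound 3 `Cn1ccc2c(Oc3ccc(NC(=O)c4nn(-c5ccc(Br)cc5)ccc4=O)cc3F)ccnc21` likewise reaches only the limit > 60000 nM in this assay. So compound 3 stands at the limit of > 60000 nM in this assay, at which 2 of the 3 values shown sit, and the step that the two limits leave unreadable from compound 2 to compound 3 cannot be read. Going by the values given here, compound 4 `Cn1ccc2c(Oc3ccc(NC(=O)c4nn(-c5ccc(Cl)c(F)c5)ccc4=O)cc3F)ccnc21` differs from compound 3 by 4-chloro-3-fluorophenyl in place of 4-bromophenyl on an aromatic nitrogen; this is the same aryl group that compound 1 carries, and compound 1 is the one compound of the set with a readable number. Compound 4 is therefore expected near the limit, and the step of an at least 1.2-fold lower number from compound 3 to compound 4 (0.07 log units; that floor lies within the scatter) is expected to stay unreadable. Compound 4 is estimated at 50000 nM, in the range 20000 nM to 120000 nM.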

Compound 4, half-maximal inhibitory concentration: 17900 nM
For compound 4 the middle estimate is 2.8-fold (0.45 log units) above the measured one, outside the stated range (below it).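

In this assay, 4-chloro-3-fluorophenyl on the aromatic nitrogen brings this fluorinated series off the assay limit, which is a limit and not a number: the limit of > 60000 nM in this assay, at which 2 of the 4 values shown sit. The aryl exchange gives an at least 3.3-fold lower number from compound 3 to compound 4 (0.52 log units; beyond the scatter), and fluoro added to the 4-chlorophenyl group gives an at least 3.3-fold lower number from compound 2 to compound 4 (0.52 log units; beyond the scatter), so this position responds to the halogen pattern. The other fluoro, on the far side of the amide, gives a 1.8-fold lower number from compound 1 to compound 4 (0.26 log units; within the scatter), which is within the scatter. The step between the two limits cannot be read. From the compounds shown here alone, whether an amine or a carboxylic acid on this aryl group would shift the number remains open.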